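Chain length and terminal group in the phenylpyridazinone series

The compounds below may be only part of what the source reports. "The series", "measured", "known", "first", "only" and "open" are said of these compounds alone.

Compound 3 `CC/N=C(\S)NCCCCCn1nc(-c2ccccc2)ccc1=O` gives 51.8 mg/kg in a functional assay on the whole organism (stomach) with Rattus norvegicus as the target; a lower number here means that less compound is needed, a higher number that more compound is needed for the effect. Among the two numbers in this assay it is the highest, with compound 2 `C/N=C(\S)NCCCCCn1nc(-c2ccccc2)ccc1=O` nearest at 35.3 mg/kg; the step of a 1.5-fold higher number from compound 2 to compound 3 (0.17 log units; within the scatter) is within the scatter, so the two cannot be ordered. Compound 1 `C/N=C(\S)NCCCn1nc(-c2ccccc2)ccc1=O` reports only a limit, > 100 mg/kg, not a number (the limit of > 100 mg/kg in this assay, at which 1 of the 3 values shown sits).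

Compound 4 `N/C(S)=N/CCCCn1nc(-c2ccccc2)ccc1=O` is not yet measured. It differs from compound 3 by a group of 4 heavy atoms (1 carbon, 2 nitrogen, 1 sulfur; no ring) in place of a group of 7 heavy atoms (4 carbon, 2 nitrogen, 1 sulfur; no ring), on a saturated chain carbon, four bonds along the chain from an aromatic nitrogen.

For the measured compounds named here, the steps that bear on this change are those that altered the chain-terminal group: an at least 2.8-fold lower number from compound 1 to compound 2 (0.45 log units; beyond the scatter) and an at least 1.9-fold lower number from compound 1 to compound 3 (0.28 log units; that floor lies within the scatter), both lowering the number when the group bound three bonds along the chain from the aromatic nitrogen was enlarged. The step of a 1.5-fold higher number from compound 2 to compound 3 (0.17 log units; within the scatter) shows that adding methyl on the chain carbon bound to the double-bonded nitrogen did not move the number beyond the scatter. Compound 4 sits between compound 1 and compound 3 in the size of the group at the chain end, so a modest rise in the number is expected, with a real chance that only a limit is reported.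

Compound 4 is expected to give 75 mg/kg, within 30 mg/kg to 200 mg/kg, a step of a 1.4-fold higher number from compound 3 to compound 4 (0.16 log units; within the scatter).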

Compound 4, dose for half-maximal effect: 36.3 mg/kg
Compound 4: middle estimate off by 2.1-fold (0.32 log units), on the high side; measured number inside the range.
By their numbers in this assay, from the lowest: compounds 2, 4 and 3 (each within the scatter of the next). At a limit, above all of these: compound 1.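

In this assay, the exchange on a saturated chain carbon, four bonds along the chain from an aromatic nitrogen, gives a 1.4-fold lower number from compound 3 to compound 4 (0.15 log units; within the scatter) and a 1.0-fold higher number from compound 2 to compound 4 (0.01 log units; within the scatter), so compound 4 cannot be ordered against compound 3 or compound 2, and the group of 4 heavy atoms is not separated from the larger groups it replaces. The size of the end group alone does not account for the series: an at least 2.7-fold lower number from compound 1 to compound 4 (0.44 log units; beyond the scatter), although the step exchanges one group of 5 heavy atoms for another of the same count, and compound 4 nevertheless stays with compound 2 and compound 3. The reading of that step rests on a floor, and compound 1 carries a limit, not a number: the limit of > 100 mg/kg in this assay, at which 1 of the 4 values shown sits.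

Compound 1 and compound 4 differ in how their atoms are distributed between chain and terminal substituent, and the compounds shown do not separate these two contributions. From the compounds shown here alone, whether a longer chain retains the effect, or whether an amine or a carboxylic acid can replace the sulfur-bearing end group, remains open.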